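The source may hold more compounds than are shown below. What is called first, only, known or untested is meant among the compounds shown, and "the series" means these compounds.

Measured so far in a physicochemical assay for lipophilicity, read by HPLC, at pH 7.4; a lower number here means a more polar compound, a higher number a more lipophilic compound:
compound 1, `CNCc1cc(-c2cccnc2F)n(S(=O)(=O)c2ccccn2)c1`, gives 0.05;
compound 2, `CNCc1cn(S(=O)(=O)c2ccccn2)c(-c2cccnc2F)c1F`, gives 0.44.

Compound 2 stands highest of these two numbers, and the step of a number 0.39 log units higher from compound 1 to compound 2 (beyond the scatter) lies beyond the scatter. Compound 3, `CNCc1cn(S(=O)(=O)c2cccc(F)n2)c(-c2cccnc2F)c1F`, has not yet been measured. The change is fluoro in place of hydrogen on an aromatic carbon, so the pyridin-2-yl group becomes 6-fluoropyridin-2-yl. Going by the values given here, only one measured step bears on it: the same kind of change, a number 0.39 log units higher from compound 1 to compound 2 (beyond the scatter), though on a different ring. A rise of similar, modest size is therefore expected, a number 0.31 log units higher from compound 2 to compound 3 (beyond the scatter). Compound 3 is estimated at 0.75, with a likely range from 0.4 to 1.1.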

Compound 3, distribution coefficient: 0.7
The estimate for compound 3 lay 0.05 log units above the measured number; measured number inside the range.
By their numbers in this assay, from the lowest: compound 1; then compounds 2 and 3 (each within the scatter of the next).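

In this assay, turning pyridin-2-yl into 6-fluoropyridin-2-yl gives a number 0.26 log units higher from compound 2 to compound 3 (within the scatter), so at this place, next to the ring nitrogen, fluoro and hydrogen cannot be told apart. The same kind of replacement on the other ring gave a number 0.39 log units higher from compound 1 to compound 2 (beyond the scatter), so one swap does not read alike at both places. Nothing measured here explains this difference. As far as these compounds go, whether chloro, methyl or methoxy at this place would give a number beyond the scatter stays open. So does the effect of fluoro on the other carbons of this ring.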